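Nitro-to-hydroxy exchange on a benzimidazole dienone series

A few compounds are considered here, and "the series" means these few. Any claim that something is new, unique, unknown or untested is made for them only; others in the source may bear on it.

Measured compounds:
compound 1 `COc1cc(/C=C/C(=O)/C=C/c2nc3cc([N+](=O)[O-])ccc3n2C)ccc1O` gives 4600 nM in a functional assay on SH-SY5Y cells (Homo sapiens) for cytotoxicity, read by MTT assay, with a stated time of 48 h; a higher number here means a weaker inhibitor, a lower number a stronger inhibitor
compound 2 `COc1cc(/C=C/C(=O)/C=C/c2nc3cc(O)ccc3n2C)ccc1O` gives 4800 nM in this assay
compound 3 `COc1ccc(/C=C/C(=O)/C=C/c2nc3cc([N+](=O)[O-])ccc3n2C)cc1O` gives 8100 nM in this assay

Compound 4 `COc1ccc(/C=C/C(=O)/C=C/c2nc3cc(O)ccc3n2C)cc1O` is not yet measured in this assay.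

The change from compound 1 to compound 2 is hydroxy in place of nitro on an aromatic carbon. Its step in this assay was a 1.0-fold higher number from compound 1 to compound 2 (0.02 log units; within the scatter). The same change, (hydroxy in place of nitro on an aromatic carbon), is made from compound 3 to compound 4; the place line reads identically for both pairs, so it is the same change.

The cores of compound 1 and compound 3 differ by 3-hydroxy-4-methoxyphenyl in place of 4-hydroxy-3-methoxyphenyl on a double-bonded chain carbon bound to a double-bonded chain carbon, with a step of a 1.8-fold higher number from compound 1 to compound 3 (0.25 log units; within the scatter) in this assay. Compound 3 thus sits within the scatter of both compound 1 and compound 2, so no ordering among the three is asserted.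

From compound 3 to compound 4 the expected step in this assay is a 1.0-fold higher number from compound 3 to compound 4 (0.01 log units; within the scatter), set beside the earlier one, because a 1.0-fold higher number from compound 1 to compound 2 (0.02 log units; within the scatter) showed no movement beyond the scatter for this exchange. With a single precedent, the width of the range is kept broad.

Compound 4 is estimated at 8300 nM in this assay, between 4000 nM and 17000 nM.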

Compound 4, half-maximal inhibitory concentration: 4600 nM
Compound 4: middle estimate off by 1.8-fold (0.26 log units), on the high side, within the range that was stated.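

In this assay, hydroxy in place of nitro on an aromatic carbon gives a 1.8-fold lower number from compound 3 to compound 4 (0.25 log units; within the scatter), so the exchange shows no movement beyond the scatter on this second core either. Among the compounds shown here, this supports carrying the exchange from the core of compound 1 to the core of compound 3 in this assay, but it rests on only two pairs and does not show that the exchange would behave the same way on any other core. It also cannot show that the exchange has no effect at all, only that neither step can be told from the scatter, and the two steps do not differ from each other beyond it: the same change on two cores in this assay, a 1.0-fold higher number (0.02 log units; within the scatter) from compound 1 to compound 2 and a 1.8-fold lower number (0.25 log units; within the scatter) from compound 3 to compound 4, 1.8-fold (0.26 log units) apart, within the scatter of two such steps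

The compounds shown leave open whether an amine, a carboxylic acid or a methoxy group on the same aromatic carbon would also stay within the scatter of nitro and hydroxy. They also leave open whether a longer chain on that carbon would move the number in this assay beyond the scatter.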